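Swapping Naphthalenyl for Fluorophenyl on a Shared Core

The compounds below may be only part of what the source reports. "The series", "measured", "known", "first", "only" and "open" are said of these compounds alone.

Compound 1, `Cc1nc(-c2cccc3ccccc23)sc1COc1ccc2c(c1)OCC2CC(=O)O`, gives "not determined" (no result reported) in a functional assay on CHO cells for agonist activity at Free fatty acid receptor 1 (Homo sapiens), read by FLIPR and calcium flux (a lower number here means that less compound is needed, a higher number that more compound is needed for the effect), so it cannot be placed on the numbers. A close relative, compound 2, `Cc1nc(-c2cccc(Cl)c2)sc1COc1ccc2c(c1)OCC2CC(=O)O`, does have one: in this assay compound 2 gives 138 nM. Compound 3, `Cc1nc(-c2cccc(F)c2)sc1COc1ccc2c(c1)OCC2CC(=O)O`, differs from compound 1 in one place: 3-fluorophenyl in place of naphthalen-1-yl on an aromatic carbon. With no number for compound 1, the size and direction of this step in this assay cannot be fixed. Going by the values given here, the only anchor is compound 2 giving 138 nM in this assay. Compound 3 is therefore expected to give about 250 nM, somewhere within 80 nM to 800 nM.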

Compound 3, half-maximal effective concentration: 64.8 nM
Compound 3: middle estimate off by 3.9-fold (0.59 log units), on the high side, outside the stated range (below it).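

Fluoro in place of chloro on an aromatic carbon gives, in this assay, a 2.1-fold lower number from compound 2 to compound 3 (0.33 log units; beyond the scatter) and so shows that even this small swap of one halogen for another can move the result at this position. The step from naphthalen-1-yl to 3-fluorophenyl cannot be read, as compound 1 has no number. Nothing available explains the shift between the two halogens.

Still open, from the compounds shown here alone, is how a nitrile or a methoxy group would compare with fluoro on this aromatic ring. An unsubstituted phenyl group is also left open as a point of comparison.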